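Swapping an aryl ether for a biaryl on the shared core

A few compounds are considered here, and "the series" means these few. Any claim that something is new, unique, unknown or untested is made for them only; others in the source may bear on it.

Measured so far in an ADME assay for permeability, using PAMPA, with a stated time of 30 min, at pH 7.4; a higher number here means that the compound crosses the layer faster, a lower number that the compound crosses the layer more slowly:
- compound 1 `CC(C)Cc1ccc2c(NCCCNCc3ccco3)ccnc2c1` gives 23 10^-6 cm/s
- compound 2 `COc1cccc(CNCCCNc2ccnc3cc(Oc4ccc(Cl)cc4)ccc23)c1O` gives 317 10^-6 cm/s
- compound 3 `COc1ccc(F)cc1CNCCCNc1ccnc2cc(-c3ccc(F)cc3)ccc12` gives 237 10^-6 cm/s

Compound 2 has the highest number of the three; compound 3 sits within the usual scatter of it, while compound 1 lies far below. Compound 4 `COc1ccc(-c2ccc3c(NCCCNCc4cccc(OC)c4O)ccnc3c2)cc1` is not yet measured. It differs from compound 2 in one place: 4-methoxyphenyl in place of 4-chlorophenoxy on an aromatic carbon. Compound 3 already carries a 4-fluorophenyl directly on an aromatic carbon of the shared core and is within the scatter of compound 2, so in this assay the change to compound 4 is expected to bring no step beyond the scatter, perhaps a slight drop, as a 1.4-fold lower number from compound 2 to compound 4 (0.14 log units; within the scatter). Compound 4 is therefore estimated at 230 10^-6 cm/s, with a range from 120 10^-6 cm/s to 420 10^-6 cm/s.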

Compound 4, apparent permeability: 237 10^-6 cm/s
The estimate for compound 4 lay 1.0-fold (0.01 log units) below the measured number; the range from low to high includes it.
By their numbers in this assay, from the lowest: compound 1; then compounds 3, 4 and 2 (each within the scatter of the next).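

In this assay, for the compounds shown here, this is the first direct comparison at this position on the shared core: 4-methoxyphenyl in place of 4-chlorophenoxy gives a 1.3-fold lower number from compound 2 to compound 4 (0.13 log units; within the scatter). Across this one pair, then, replacing the chlorinated aryl ether with a methoxylated aryl group directly on the core leaves the read-out within the scatter. Nothing available explains this result. One pair cannot show whether the position would stay as undemanding with a much smaller group. A methyl group, an amine or a carboxylic acid there remains an open case.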